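Thiophen-2-yl for Phenyl on Two Related Nucleoside Cores

The source may hold more compounds than are shown below. What is called first, only, known or untested is meant among the compounds shown, and "the series" means these compounds.

Three nucleoside analogues have been tested in an ADME assay on BJ cells (Homo sapiens), read by MTT assay, with a stated time of 72 h; a lower number here means a stronger inhibitor, a higher number a weaker inhibitor. Compound 1 `Cc1nc(N)c2c(-c3ccccc3)cn([C@@H]3O[C@H](CO)[C@@H](O)[C@H]3O)c2n1` carries a phenyl group on its fused core. In this assay compound 1 gives only a limit, > 100000 nM. Compound 2 `Cc1nc(N)c2c(-c3cccs3)cn([C@@H]3O[C@H](CO)[C@@H](O)[C@H]3O)c2n1` differs from compound 1 by thiophen-2-yl in place of phenyl on an aromatic carbon. In this assay compound 2 likewise gives only a limit, > 100000 nM. The step that the two limits leave unreadable from compound 1 to compound 2 therefore cannot be read from the two values. Compound 3 `CNc1ncnc2c1c(-c1ccccc1)cn2[C@@H]1O[C@H](CO)[C@@H](O)[C@H]1O` is built from the same atoms as compound 1, joined differently; the difference between the two cores is not broken down here. In this assay compound 3 also gives only a limit, > 100000 nM. Compound 4 `CNc1ncnc2c1c(-c1cccs1)cn2[C@@H]1O[C@H](CO)[C@@H](O)[C@H]1O` has not yet been measured and differs from compound 3 by thiophen-2-yl in place of phenyl on an aromatic carbon. The groups that leave and enter, and the place where this happens, match the change from compound 1 to compound 2 word for word, so this is the same change made on the second core. Going by the values given here, all three values so far stand at the limit of > 100000 nM in this assay, at which 3 of the 3 values shown sit, and the change on the first core left compound 2 at that limit just as compound 1. For compound 4 the step that the limit leaves unreadable from compound 3 to compound 4 is expected to be unreadable in the same way, because compound 3 stands at the limit of > 100000 nM in this assay, at which 3 of the 3 values shown sit. Compound 4 is therefore expected to be reported again only as a limit, with an estimate of 150000 nM and a range from 50000 nM to 500000 nM.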

Compound 4, half-maximal inhibitory concentration: > 100000 nM
Compound 4: no number, only a limit; the forecaster's own chance of this, stated with the estimate: 90%; the middle value lies beyond the limit too.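

In this assay compound 4 gives > 100000 nM as a limit and not a number. Compound 3 also has only a limit, so no size can be read for the change from phenyl to thiophen-2-yl between compound 3 and compound 4. The compounds shown leave open how strongly any of them acts on these cells and whether the change matters, because all stand at one limit: the limit of > 100000 nM in this assay, at which 4 of the 4 values shown sit.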